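This account rests on a few compounds, and the source may have more. Where it says the series, first, only, none or still open, it means among the compounds named here.

Working notes on the series. Compound 3 `COc1cc(/C=C/c2ccc(NC(=O)/C=C/c3ccc(Br)cc3)cc2)cc(OC)c1` carries 4-bromophenyl on the cinnamamide arm of the shared core, and in a functional assay on MDA-MB-231 cells (Homo sapiens) for inhibition, read by MTT assay, with a stated time of 48 h (a lower number here means a stronger inhibitor, a higher number a weaker inhibitor), compound 3 gives 6160 nM, the lowest of the two numbers reported so far. Its nearest neighbour is compound 1 `COc1cc(/C=C/c2ccc(NC(=O)/C=C/c3ccc([N+](=O)[O-])cc3)cc2)cc(OC)c1`, which in this assay gives 11700 nM; the step of a 1.9-fold lower number from compound 1 to compound 3 (0.28 log units; within the scatter) stays within the scatter. Compound 2 `COc1cc(/C=C/c2ccc(NC(=O)/C=C/c3ccc(F)cc3F)cc2)cc(OC)c1` reaches only a limit of this assay, > 20000 nM (the limit of > 20000 nM in this assay, at which 1 of the 3 values shown sits). The step of an at least 3.2-fold lower number from compound 2 to compound 3 (0.51 log units; beyond the scatter) is the one clear move among the measured pairs.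

Compound 4 `COc1cc(/C=C/c2ccc(NC(=O)/C=C/c3ccc(O)c(O)c3)cc2)cc(OC)c1` is not yet measured. It differs from compound 3 by 3,4-dihydroxyphenyl in place of 4-bromophenyl on a double-bonded chain carbon bound to a double-bonded chain carbon. For the measured compounds named here, none of the measured steps introduces hydrogen-bond donors on this ring, so the only guide is that swapping aromatic substituents here has moved the numbers by a 1.9-fold lower number from compound 1 to compound 3 (0.28 log units; within the scatter) and an at least 3.2-fold lower number from compound 2 to compound 3 (0.51 log units; beyond the scatter). A step of a 1.3-fold higher number from compound 3 to compound 4 (0.11 log units; within the scatter) is expected for compound 4. In this assay compound 4 is estimated at 8000 nM, with a range from 2500 nM to 25000 nM.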

Compound 4, half-maximal inhibitory concentration: 4230 nM
For compound 4 the middle estimate is 1.9-fold (0.28 log units) above the measured one, and the stated range covers the measured number.
By their numbers in this assay, from the lowest: compounds 4, 3 and 1 (each within the scatter of the next, the first and the last beyond it). At a limit, above all of these: compound 2.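

3,4-Dihydroxyphenyl is the first group at this place to bring hydrogen-bond donors, yet in this assay it cannot be told apart from 4-bromophenyl, which has none: a 1.5-fold lower number from compound 3 to compound 4 (0.16 log units; within the scatter). For the compounds shown here, it is, however, the first group to move clearly away from 4-nitrophenyl, with the step of a 2.8-fold lower number from compound 1 to compound 4 (0.44 log units; beyond the scatter), a separation that 4-bromophenyl did not reach. The step of an at least 4.7-fold lower number from compound 2 to compound 4 (0.67 log units; beyond the scatter) is only a floor, as compound 2 stands at a limit of the assay: the limit of > 20000 nM in this assay, at which 1 of the 4 values shown sits.

The compounds shown cannot say whether the hydrogen-bond donors matter at all, given that compounds with and without them fall within the scatter of each other. Also open, going by these compounds, is whether a single hydroxyl, a methoxy group or an amine on this ring would give a number like that of compound 4.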